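Opening the amine side of a quinolone-like topoisomerase series

A few compounds are considered here, and "the series" means these few. Any claim that something is new, unique, unknown or untested is made for them only; others in the source may bear on it.

Compounds measured so far in an assay on isolated protein for inhibition of DNA topoisomerase 1 (Homo sapiens), with a stated time of 15 min; a higher number here means a weaker inhibitor, a lower number a stronger inhibitor:
compound 1 `COc1c(N2CC[C@@H](CO)C2)c(F)cc2c(=O)c(C(=O)O)cn(Cc3ccc(-c4ccccc4)cc3)c12` – > 200000 nM
compound 2 `COc1c(N2CC[C@@H](CN)C2)c(F)cc2c(=O)c(C(=O)NO)cn(Cc3ccc(-c4ccccc4)cc3)c12` – 35900 nM
compound 3 `COc1c(N2CC[C@@H](CN)C2)c(F)cc2c(=O)c(C(N)=O)cn(Cc3ccc(-c4ccccc4)cc3)c12` – 184000 nM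

Compound 1 carries a carboxylic acid on the shared core, and in this assay compound 1 reaches only the assay limit, (the limit of > 200000 nM in this assay, at which 1 of the 3 values shown sits), so no number stands for it. Going by the values given here, compounds 2 and 3 differ from it on the acid side, and the one measured step between them, a 5.1-fold higher number from compound 2 to compound 3 (0.71 log units; beyond the scatter), concerns that side alone; it says nothing about the amine side, which is where compound 4 `CNCCCCNc1c(F)cc2c(=O)c(C(=O)O)cn(Cc3ccc(-c4ccccc4)cc3)c2c1OC` departs from compound 1: (4-(methylamino)butyl)amino in place of 3-(hydroxymethyl)pyrrolidin-1-yl on an aromatic carbon. Among the compounds with values here, compound 4 keeps the carboxylic acid of compound 1, and no measured pair speaks to swapping the ring for the open chain, so the expectation leans on the limit of compound 1 alone. The account therefore expects compound 4 to stay weak, a number no higher from compound 1 to compound 4 (the limit leaves the size open), with a real chance of another limit. The estimate for compound 4 in this assay is 200000 nM, between 40000 nM and 600000 nM.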

Compound 4, half-maximal inhibitory concentration: > 200000 nM
Compound 4 ended at the assay's limit; the forecaster's own chance of this, stated with the estimate: 60%; the middle value sits exactly at the limit.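

Compound 1 and compound 4 both stop at the assay's limit, so no step can be read between them: the limit of > 200000 nM in this assay, at which 2 of the 4 values shown sit.

The compounds shown leave open whether (4-(methylamino)butyl)amino in place of 3-(hydroxymethyl)pyrrolidin-1-yl changes inhibition at all, with the carboxylic acid or with any other group on the acid side.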